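Benzyltriazole chromone series: halogen pattern on the benzyl ring

This account rests on a few compounds, and the source may have more. Where it says the series, first, only, none or still open, it means among the compounds named here.

Measured so far, in a functional assay on A549 cells (Homo sapiens) for cytotoxicity, read by MTT assay, with a stated time of 48 h; a higher number here means a weaker inhibitor, a lower number a stronger inhibitor:
- compound 1, `O=c1ccoc2cc(OCc3cn(Cc4ccc(Cl)cc4)nn3)ccc12`, reports only a limit, > 100000 nM
- compound 2, `O=c1ccoc2cc(OCc3cn(Cc4ccc(Cl)cc4Cl)nn3)ccc12`, gives 5260 nM
- compound 3, `O=c1ccoc2cc(OCc3cn(Cc4cccc(F)c4)nn3)ccc12`, reports only a limit, > 100000 nM

Going by the values given here, compound 3 therefore stands at the limit of this assay, as does one further value in the set (the limit of > 100000 nM in this assay, at which 2 of the 3 values shown sit); compound 2 is the only compound with a number.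

Compound 4, `O=c1ccoc2cc(OCc3cn(Cc4ccc(Br)cc4)nn3)ccc12`, differs from compound 3 in one place: 4-bromophenyl in place of 3-fluorophenyl on a saturated chain carbon bound to an aromatic nitrogen.

Among the compounds with values here, two measured steps touch this change. an at least 19-fold higher number from compound 2 to compound 3 (1.27 log units; beyond the scatter) shows that the 2,4-dichlorophenyl compound is the sole one clearly apart from the limit. a step that the two limits leave unreadable from compound 1 to compound 3 cannot be read, since both ends are limits. Compound 1 carries a 4-chlorophenyl, the closest relative of the 4-bromophenyl entering in compound 4, and compound 1 sits at the limit. The only readable gain, an at least 19-fold lower number from compound 1 to compound 2 (1.27 log units; beyond the scatter), came with a second chloro, which compound 4 lacks.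

For compound 4 the step of a number no higher from compound 3 to compound 4 (the limit leaves the size open) is therefore expected to stay within the scatter, most likely ending again at a limit. The estimate for compound 4 in this assay is 100000 nM, with a range from 20000 nM to 300000 nM.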

Compound 4, half-maximal inhibitory concentration: > 100000 nM
Compound 4: no number, only a limit; the forecaster's own chance of this, stated with the estimate: 70%; the middle value lies on the limit itself.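

In this assay compound 4 reports only a limit, > 100000 nM. The steps from compound 3 to compound 4 and from compound 1 to compound 4 cannot be read, since both ends of each are limits, so no order can be given among these three compounds. The one readable new step, an at least 19-fold higher number from compound 2 to compound 4 (1.27 log units; beyond the scatter), leaves the 2,4-dichlorophenyl of compound 2 as the only group here with a number, and 4-chlorophenyl, 3-fluorophenyl and 4-bromophenyl, each carrying a single halogen on the ring, all stay at the limit, so replacing chloro with bromo in this place gives no readable gain: the limit of > 100000 nM in this assay, at which 3 of the 4 values shown sit.

The compounds shown leave open whether the gain in compound 2 depends on chloro itself or on the two-halogen pattern, which a 2,4-dibromophenyl or a 2-chlorophenyl group in the same place would help to separate. They also leave open whether a group other than a halogen on the benzyl ring, such as a methoxy or a dimethylamino group, can bring a compound of this series off the limit.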